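This account rests on a few compounds, and the source may have more. Where it says the series, first, only, none or still open, it means among the compounds named here.

Measured so far:
- Compound 1, `O=S(=O)(Nc1ccc(-c2nc3cc(NS(=O)(=O)c4ccccc4)ccc3o2)cc1)c1ccccc1`, in an assay on cells for inhibition of HSP60/HSP10 (Homo sapiens), with a stated time of 60 min (on this read-out lower numbers stand for stronger inhibition and higher numbers for weaker inhibition), gives 80000 nM.
- Compound 2, `Cc1ccc(S(=O)(=O)Nc2ccc(-c3nc4ccccc4o3)cc2)cc1`, in this assay reaches only the assay limit of > 100000 nM.
- Compound 3, `O=S(=O)(Nc1ccc(-c2nc3ccccc3o2)cc1)c1ccccc1Cl`, in this assay likewise reaches only the assay limit of > 100000 nM.

Compound 3 therefore stands at the limit of this assay, not at a number, and the same holds for compound 2, as the evidence shows: the limit of > 100000 nM in this assay, at which 2 of the 3 values shown sit. Only compound 1 gives a measured figure, and that figure is weak. Compound 4, `O=S(=O)(Nc1ccc(-c2nc3ccccc3o2)cc1)c1cccc(Cl)c1`, has not yet been tested. It differs from compound 3 in one place: 3-chlorophenyl in place of 2-chlorophenyl on a sulfonyl sulfur.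

For the measured compounds named here, the one measured step that touches this part of the structure is the change of the aryl group on the sulfonyl sulfur, a step that the two limits leave unreadable from compound 2 to compound 3. Both ends of that step sit at the limit. Its size cannot be read. With compound 3 at the limit and no readable step to lean on, the move of the chlorine from the 2-position to the 3-position of the phenyl group is expected to yield no step beyond the scatter, a step that the limit leaves unreadable from compound 3 to compound 4. Compound 4 is thus estimated at 120000 nM, within 40000 nM to 400000 nM, most likely again reported only as a limit.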

Compound 4, half-maximal inhibitory concentration: 54000 nM
Beside the measured number, compound 4's estimate is 2.2-fold (0.35 log units) above it; measured number inside the range.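

Compound 4 gives a measured number, whereas compound 2 and compound 3, which differ from it only in the aryl group on the sulfonyl sulfur, do not. Having 3-chlorophenyl in place of 2-chlorophenyl gives an at least 1.8-fold lower number from compound 3 to compound 4 (0.26 log units; that floor lies within the scatter), and having 3-chlorophenyl in place of 4-methylphenyl gives an at least 1.8-fold lower number from compound 2 to compound 4 (0.26 log units; that floor lies within the scatter). Each step is only a floor, so neither is shown to lie beyond the scatter, and the true sizes stay unknown because compound 2 and compound 3 each sit at a limit: the limit of > 100000 nM in this assay, at which 2 of the 4 values shown sit.

From the compounds shown here alone, whether an amine or a carboxylic acid in place of the chlorine on this phenyl ring would give a clearly lower number remains open. Also open, going by these compounds, is whether 3-chlorophenyl on the sulfonyl sulfur would change the value of compound 1, which stands at 80000 nM.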